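A few compounds are considered here, and "the series" means these few. Any claim that something is new, unique, unknown or untested is made for them only; others in the source may bear on it.

In a functional assay on HepG2 cells (Homo sapiens) for inhibition, read by MTT assay (on this read-out lower numbers stand for stronger inhibition and higher numbers for weaker inhibition), two amides built on a shared core have been measured so far. Compound 1 `COc1cc2ncnc(Nc3ccc(NC(=O)c4ccccc4C)cc3)c2cc1OC` gives 15000 nM, and compound 2 `COc1cc2ncnc(Nc3ccc(NC(=O)c4cccc(I)c4)cc3)c2cc1OC` gives 28000 nM. For the measured compounds named here, compound 2 therefore stands within the scatter of compound 1, the only other compound with a number. Compound 3 `COc1cc2ncnc(Nc3ccc(NC(=O)c4ccc(C(F)(F)F)cc4)cc3)c2cc1OC` keeps the shared core and the amide, and the change from compound 2 is 4-(trifluoromethyl)phenyl in place of 3-iodophenyl on a carbonyl carbon. Going by the values given here, the single measured step that bears on this is a 1.9-fold higher number from compound 1 to compound 2 (0.27 log units; within the scatter), which also exchanges the aromatic group on the carbonyl carbon. Among the compounds with values here, no measured compound carries the 4-(trifluoromethyl)phenyl group, so its own contribution remains unknown. On that one small step, no change beyond the scatter is expected in this assay. The expected step is a 1.4-fold lower number from compound 2 to compound 3 (0.15 log units; within the scatter). Compound 3 is estimated at 20000 nM, with an expected range of 9000 nM to 45000 nM.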

Compound 3, half-maximal inhibitory concentration: > 100000 nM
Compound 3: no number, only a limit; the forecaster's own chance of this, stated with the estimate: 10%; at least 5.0-fold (0.69 log units) between middle value and limit.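

In this assay, the aromatic group on the carbonyl carbon proves not to be freely exchangeable: 4-(trifluoromethyl)phenyl in place of 3-iodophenyl gives an at least 3.5-fold higher number from compound 2 to compound 3 (0.55 log units; beyond the scatter), and in place of 2-methylphenyl it gives an at least 6.6-fold higher number from compound 1 to compound 3 (0.82 log units; beyond the scatter). For the compounds shown here, the earlier exchange between compound 1 and compound 2 stayed within the scatter, so this is the first change at this place that reaches beyond it. Compound 3 gives > 100000 nM, which is a limit and not a number, and the full size of both steps stays unknown: the limit of > 100000 nM in this assay, at which 1 of the 3 values shown sits.

Whether the trifluoromethyl group itself goes with this weakening stays open, as no other compound shown carries it. Nor do the compounds shown tell how a phenyl ring bearing an amine or a carboxylic acid would read at this place in this assay.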